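A few compounds are considered here, and "the series" means these few. Any claim that something is new, unique, unknown or untested is made for them only; others in the source may bear on it.

In an assay on CHO cells for binding affinity to Melanocortin receptor 4 (Homo sapiens) (a lower number here means a stronger inhibitor, a higher number a weaker inhibitor), compound 1 `COc1ccc(-n2nc(Sc3ccc(Cl)cc3)cc(CC[C@@H](C)NC(=O)[C@H]3CNCC[C@@H]3c3ccc(Cl)cc3)c2=O)cc1` gives 2.4 nM, the lowest of the three numbers in hand. Compound 2 `COc1ccc(-n2nc(Sc3ccc(Cl)cc3)cc(CC[C@@H](C)NC(=O)[C@H]3CNCC[C@@H]3c3cccc(Cl)c3)c2=O)cc1` gives 43 nM and compound 3 `COc1ccc(-n2nc(Sc3ccc(Cl)cc3)cc(CC[C@@H](C)NC(=O)[C@H]3CNCC[C@@H]3c3ccccc3F)c2=O)cc1` gives 13 nM. Both measured steps away from compound 1 touch the aryl group on the saturated ring carbon: an 18-fold higher number from compound 1 to compound 2 (1.25 log units; beyond the scatter), and a 5.4-fold higher number from compound 1 to compound 3 (0.73 log units; beyond the scatter). Between the other two, a 3.3-fold lower number from compound 2 to compound 3 (0.52 log units; beyond the scatter).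

Compound 4 `COc1ccc(-n2nc(Sc3ccc(Cl)cc3)cc(CC[C@@H](C)NC(=O)[C@H]3CNCC[C@@H]3c3ccc(C)cc3)c2=O)cc1` differs from compound 1 in one place: methyl in place of chloro on an aromatic carbon. Neither measured step tests this exchange directly. Both of them replace the 4-chlorophenyl with a differently placed halogen and both cost potency beyond the scatter, so the aryl group here is clearly sensitive to change. The step to compound 4, however, keeps the substituent where it stands and alters only its identity, which in this series is the least drastic of the changes tried so far. The expectation for this assay is therefore a weakening smaller than that seen with compound 3, or none beyond the scatter. The expected step is a 2.1-fold higher number from compound 1 to compound 4 (0.32 log units; beyond the scatter). Compound 4 is estimated at 5 nM, with a range from 2 nM to 15 nM.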

Compound 4, half-maximal inhibitory concentration: 4.7 nM
Estimate against measurement, compound 4: 1.1-fold (0.03 log units) above; the range from low to high includes it.
By their numbers in this assay, from the lowest: compounds 1 and 4 (each within the scatter of the next); then compound 3; then compound 2.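

In this assay, a 2.0-fold higher number from compound 1 to compound 4 (0.29 log units; within the scatter) shows that the substituent para to a large group need not be chloro: a methyl in the same place leaves the number within the scatter, the first sign that this position accepts a non-halogen. The other new steps, a 2.8-fold lower number from compound 3 to compound 4 (0.44 log units; beyond the scatter) and a 9.1-fold lower number from compound 2 to compound 4 (0.96 log units; beyond the scatter), place compound 4 with compound 1 on the low side of compounds 2 and 3, so among these four compounds, both para-substituted aryl groups give lower numbers than the two others, with no compound against this; but each of these steps alters the substituent and its place together, so they do not separate the two changes. No measured evidence bears on why chloro and methyl can be exchanged here.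

On these data alone, it remains open whether the same place also accepts a methoxy, a trifluoromethyl, an amine or a carboxylic acid, and how a plain phenyl with no substituent compares. A fluoro in the place of the chloro of compound 1 would show how much of the gap to compound 3 follows the substituent and how much follows its place.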